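This account rests on a few compounds, and the source may have more. Where it says the series, first, only, none or still open, it means among the compounds named here.

Measured compounds:
compound 1, `C=Cc1c(CCC)nn(CCCN2CCN(c3ccc(C)cc3)CC2)c(=O)c1N`, giving 22% in a functional assay on the whole organism (Abdomen, strain Swiss) for inhibition, with Mus musculus as the target, with stated times of 30 min, 10 min and 5 min, at a dose of 40 mg/kg by the oral route; a higher number here means a stronger effect of the compound at the dose given, a lower number a weaker effect
compound 2, `C=Cc1c(CCCC)nn(CCCN2CCN(c3ccc(C)cc3)CC2)c(=O)c1N`, giving 48% in this assay
compound 3, `CC/C=C/c1c(C)nn(CCCN2CCN(c3ccc(C)cc3)CC2)c(=O)c1N`, giving 45% in this assay

The step from compound 1 to compound 2 is a number 26 percentage points higher from compound 1 to compound 2 (beyond the scatter), and the change behind it is methyl in place of hydrogen on a saturated chain carbon, three bonds along the chain from an aromatic carbon. Compound 4, `CCC/C=C/c1c(C)nn(CCCN2CCN(c3ccc(C)cc3)CC2)c(=O)c1N`, is not yet measured in this assay. It differs from compound 3 by the same kind of change, (methyl in place of hydrogen on a saturated chain carbon, two bonds along the chain from a double-bonded chain carbon), but the place is not the same: here the saturated chain carbon lies two bonds along the chain from a double-bonded chain carbon, not three bonds along the chain from an aromatic carbon. The difference between the core of compound 1 and the core of compound 3 is not broken down here. Because a number 26 percentage points higher from compound 1 to compound 2 (beyond the scatter) was modest and sits at a different place, a smaller step is expected here, a number 10 percentage points higher from compound 3 to compound 4 (within the scatter). Compound 4 is expected to give 55%, estimated between 35% and 75%.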

Compound 4, a percentage reported as inhibition, in the whole organism at one dose (the size of the read-out at that dose, not a potency): 36%
Estimate against measurement, compound 4: 19 percentage points above, within the range that was stated.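

In this assay, the added methyl gives a number 9 percentage points lower from compound 3 to compound 4 (within the scatter), so this step does not separate compound 4 from compound 3. The same kind of change therefore did not carry over from one core to the other with the same size: the same change on two cores in this assay, a number 26 percentage points higher (beyond the scatter) from compound 1 to compound 2 and a number 9 percentage points lower (within the scatter) from compound 3 to compound 4, 35 percentage points apart, beyond the scatter of two such steps

This does not show why the two steps differ: the methyl sits at a different place on each core, so the effect of the core cannot be separated from that of the place, and one pair per core gives no general rule.

The compounds shown leave open how a longer chain would behave on either core. They also leave open what a hydroxyl group or an amine would do in place of the added methyl.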